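The compounds below may be only part of what the source reports. "The series", "measured", "known", "first", "only" and "open" are said of these compounds alone.

Compound 1 `CCc1oc2cc(OC)ccc2c1C(=O)c1ccc(OC)cc1` gives 6.2% in an assay for inhibition of solute carrier family 22 member 12 (Homo sapiens), read by scintillation counting, with a stated time of 60 min, tested at 50 uM (on this read-out higher numbers stand for more inhibition at the one concentration tested (going by the name of the read-out) and lower numbers for less inhibition), the lowest of the three numbers measured. Compound 2 `CCc1cc2c(C(=O)c3ccc(O)cc3)c(O)ccc2o1` gives 51.5%, and compound 3 `CCc1oc2cc(OC)ccc2c1C(=O)c1ccc(O)cc1` gives 92.7%. Among the measured compounds shown here, the one measured step of a single change runs from compound 1 to compound 3 a number 86.5 percentage points higher from compound 1 to compound 3 (beyond the scatter): hydrogen in place of methyl on an oxygen on an aromatic ring. Compound 4 `CCc1oc2cc(O)ccc2c1C(=O)c1ccc(OC)cc1` carries the same kind of change, (hydrogen in place of methyl on an oxygen on an aromatic ring), but at the other oxygen of the core of compound 1. For the measured compounds named here, only the step to compound 3 bears on it, and it came at a different place, so the transfer is uncertain. A rise beyond the scatter is expected, but a smaller one. Compound 4 is estimated at 30%, within 5% to 65%. The expected step is a number 23.8 percentage points higher from compound 1 to compound 4 (beyond the scatter).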

Compound 4, a percentage reported as inhibition, at one concentration (the size of the read-out at that concentration, not a potency): 48.3%
The estimate for compound 4 lay 18.3 percentage points below the measured number, and the stated range covers the measured number.
By their numbers in this assay, from the lowest: compound 1; then compounds 4 and 2 (each within the scatter of the next); then compound 3.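

In this assay, the methoxy to hydroxy change also raises inhibition at this second oxygen, giving a number 42.1 percentage points higher from compound 1 to compound 4 (beyond the scatter). The gain is therefore not limited to one oxygen, although it is smaller here than the other step, a number 86.5 percentage points higher from compound 1 to compound 3 (beyond the scatter). Nothing measured here explains why either change raises the number. Going by these compounds, it remains open whether a compound with hydroxy at both oxygens would add the two gains. On these data alone, it is also open whether an amine or a carboxylic acid in place of this hydroxy would keep the inhibition.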